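Swapping the Hydroxyethyl for an Oxanyl Ring

The source may report more compounds than this note shows. Statements on the series, on what has been measured and on what is new or still open speak of the compounds shown alone.

Compound 1 `COc1ccc(-c2c(-c3ccc(OC)cc3)n(Cc3ccccc3)c3ncn([C@H]4CC[C@H](O)CC4)c(=N)c23)cc1` and compound 2 `COc1ccc(-c2c(-c3ccc(OC)cc3)n(Cc3ccccc3)c3ncn(CCO)c(=N)c23)cc1` share one core and differ only in the group carried on an aromatic nitrogen. In an ADME assay for permeability, using PAMPA, with a stated time of 30 min, at pH 7.4 (on this read-out lower numbers stand for lower permeability and higher numbers for higher permeability), compound 1 gives 196 10^-6 cm/s. In this assay compound 2 gives > 1000 10^-6 cm/s, which is a limit of the measurement rather than a number. That gives an at least 5.1-fold higher number from compound 1 to compound 2 (0.70 log units; beyond the scatter), and so compound 2 sits at the limit of > 1000 10^-6 cm/s in this assay, at which 1 of the 2 values shown sits, the top of what can be read.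

Compound 3 `COc1ccc(-c2c(-c3ccc(OC)cc3)n(Cc3ccccc3)c3ncn(C4CCOCC4)c(=N)c23)cc1` has not yet been measured. It differs from compound 2 by oxan-4-yl in place of 2-hydroxyethyl on an aromatic nitrogen. Within the data shown here, neither measured compound carries this group, so only the one measured step, which went upward, offers guidance. Compound 3 is expected to remain near the top of the readable range, so the step is expected to be an at least 1.1-fold lower number from compound 2 to compound 3 (0.04 log units; that floor lies within the scatter). Compound 3 is estimated at 900 10^-6 cm/s, with a range from 400 10^-6 cm/s to 1500 10^-6 cm/s.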

Compound 3, apparent permeability: > 1000 10^-6 cm/s
Compound 3: no number, only a limit; the forecaster's own chance of this, stated with the estimate: 45%; middle value at least 1.1-fold (0.04 log units) from the limit.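

In this assay compound 3 gives > 1000 10^-6 cm/s, which is a limit of the assay and not a number. Oxan-4-yl in place of 4-hydroxycyclohexyl gives an at least 5.1-fold higher number from compound 1 to compound 3 (0.70 log units; beyond the scatter), so a six-membered non-aromatic ring on this aromatic nitrogen does not in itself keep the number as low as it is in compound 1. The step between compound 2 and compound 3 cannot be read, and the two groups cannot be ranked, as both values are limits: the limit of > 1000 10^-6 cm/s in this assay, at which 2 of the 3 values shown sit.

As far as these compounds go, how far apart compound 2 and compound 3 truly lie stays open. Also open, from the compounds shown here alone, is whether a group carrying an amine or a carboxylic acid on this nitrogen would bring the number back within the readable range.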